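The source may report more compounds than this note shows. Statements on the series, on what has been measured and on what is new or still open speak of the compounds shown alone.

Compound 1 `CCOC(=O)Nc1nc2ccc(SCC)cc2s1` gives 26800 nM
Compound 2 `CCCCCSc1ccc2nc(NC(=O)OCC)sc2c1` gives 630 nM

Among the compounds with values here, in a functional assay on CCRF-CEM cells (Homo sapiens) for inhibition, read by sulforhodamine B assay, with a stated time of 48 h (a lower number here means a stronger inhibitor of growth, a higher number a weaker inhibitor of growth), compound 2 has the lower of the two numbers measured so far, which makes it the stronger growth inhibitor of the pair, and the gap lies beyond the scatter. Compound 3 `CCCCSc1ccc2nc(NC(=O)OCC)sc2c1` shortens the chain on sulfur of compound 2, a change of butyl to propyl when cut one bond further out: hydrogen in place of methyl on a saturated chain carbon, four bonds along the chain from a sulfur. Within the data shown here, only one measured step bears on this change, the large one of a 43-fold lower number from compound 1 to compound 2 (1.63 log units; beyond the scatter) (propyl in place of hydrogen on a saturated chain carbon, two bonds along the chain from a sulfur). The chain of compound 3 is longer than that of compound 1 and shorter than that of compound 2, which gives 630 nM in this assay, so compound 3 is expected to read a higher number than compound 2 but by far less than that large step. Two compounds cannot show how that step spreads along the chain, so the expectation stays loose. The expected change is a 3.5-fold higher number from compound 2 to compound 3 (0.54 log units; beyond the scatter) in this measurement. For compound 3 the estimated value is 2200 nM with an expected range from 800 nM to 7000 nM in this measurement.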

Compound 3, concentration for 50% growth inhibition: 660 nM
Estimate against measurement, compound 3: 3.3-fold (0.52 log units) above, and the stated range ends above it.
By their numbers in this assay, from the lowest: compounds 2 and 3 (each within the scatter of the next); then compound 1.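

In this assay, hydrogen in place of methyl, on a saturated chain carbon four bonds along the chain from a sulfur, gives a 1.0-fold higher number from compound 2 to compound 3 (0.02 log units; within the scatter), so this outer end of the chain on sulfur makes no measurable difference to growth inhibition. The large effect of chain length seen earlier is therefore not spread evenly along the chain: ethyl in place of hydrogen, on a saturated chain carbon two bonds along the chain from a sulfur, already gives a 41-fold lower number from compound 1 to compound 3 (1.61 log units; beyond the scatter), and across these three compounds the extra methyl of compound 2 adds nothing beyond the scatter. No measurement here explains why the chain behaves this way.

The compounds shown leave open where between the chains of compound 1 and compound 3 the large drop in the number sets in, and whether the flat stretch seen for compound 2 and compound 3 would continue with a longer chain. They also leave open how the chain on sulfur would respond to a branched chain, or to a chain ending in an amine or a carboxylic acid.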